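This account rests on a few compounds, and the source may have more. Where it says the series, first, only, none or still open, it means among the compounds named here.

Of the compounds shown here, three sharing one core have been tested in a functional assay on HEK293 cells (Homo sapiens) for cytotoxicity; on this read-out lower numbers stand for higher toxicity in this test and higher numbers for lower toxicity in this test. Compound 1, `COc1ccc([C@H]2CC(=O)N(c3ccc(C#N)cc3)C2)cc1OC1CCCC1`, gives > 10000 nM, which is a limit of the assay rather than a number. Compound 2, `COc1ccc([C@H]2CC(=O)N(c3cccc(NCC4CCOC4)c3)C2)cc1OC1CCCC1`, likewise reaches only the limit > 10000 nM. Compound 3, `COc1ccc([C@H]2CC(=O)N(c3cccc(NS(=O)(=O)c4cccc(OC(F)(F)F)c4)c3)C2)cc1OC1CCCC1`, also stops at the limit, > 10000 nM. For the measured compounds named here, no step between two measured compounds can therefore be read. Compound 4, `COc1ccc([C@H]2CC(=O)N(c3cccc(NS(=O)(=O)c4cccc(Br)c4)c3)C2)cc1OC1CCCC1`, remains to be measured; it differs from compound 3 by bromo in place of trifluoromethoxy on an aromatic carbon. Because all three values sit at the limit of > 10000 nM in this assay, at which 3 of the 3 values shown sit, the step that the limit leaves unreadable from compound 3 to compound 4 is expected to show no change beyond the scatter. For compound 4 a value of 20000 nM is estimated, within 8000 nM to 60000 nM, most likely again reported only as a limit.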

Compound 4, half-maximal cytotoxic concentration: > 10000 nM
Compound 4 ended at the assay's limit (the forecaster's own chance of this, stated with the estimate: 85%); the middle value is on the limit's open side.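

The steps from compound 3 to compound 4 and from compound 2 to compound 4 cannot be read, as compound 4 also gives only a limit: the limit of > 10000 nM in this assay, at which 4 of the 4 values shown sit.

The compounds shown leave open whether any change to the shared core would give a measurable number in this assay.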